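The source may hold more compounds than are shown below. What is called first, only, known or untested is meant among the compounds shown, and "the series" means these compounds.

Compound 1 `C/C1=C\CC[C@@]2(C)O[C@@H]2[C@H]2OC(=O)[C@@H](CN3CCN(c4ccccc4)CC3)[C@@H]2C[C@H]1O` and compound 2 `C/C1=C\CC[C@@]2(C)O[C@@H]2[C@H]2OC(=O)[C@@H](CN3CCN(c4ccccc4F)CC3)[C@@H]2C[C@H]1O` share one core, while compound 3 `C[C@]12O[C@@H]1CC[C@@]1(C)O[C@@H]1[C@H]1OC(=O)[C@@H](CN3CCN(c4ccccc4)CC3)[C@@H]1C[C@H]2O` and compound 4 `C[C@]12O[C@@H]1CC[C@@]1(C)O[C@@H]1[C@H]1OC(=O)[C@@H](CN3CCN(c4ccccc4F)CC3)[C@@H]1C[C@H]2O` share another; how the two cores differ is not broken down here. In a functional assay on B16-F10 cells (Mus musculus) for inhibition, read by colorimetric assay and MTT assay, with a stated time of 72 h (a higher number here means a weaker inhibitor, a lower number a stronger inhibitor), compound 1 gives 6000 nM, and compound 2 gives 6000 nM. The change from compound 1 to compound 2 is fluoro in place of hydrogen on an aromatic carbon, and it made no change at the digits printed from compound 1 to compound 2 (within the scatter). In this assay compound 3 gives 22000 nM, the highest of the three numbers, with compound 1 and compound 2 each showing a lower number by a margin beyond the scatter. Compound 4 carries the same change on the core of compound 3: fluoro in place of hydrogen on an aromatic carbon. Because the same change once made no change at the digits printed from compound 1 to compound 2 (within the scatter), the step is expected to be no change at the digits printed from compound 3 to compound 4 (within the scatter). The estimate for compound 4 in this assay is 22000 nM, resting on compound 3 at 22000 nM and on that single earlier step. Within the data shown here, only one prior example of this change exists here, so the expectation is held loosely.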

Compound 4, half-maximal inhibitory concentration: 5000 nM
For compound 4 the middle estimate is 4.4-fold (0.64 log units) above the measured one, and the stated range ends above it.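

Phenyl to 2-fluorophenyl did not behave alike on the two cores in this assay: the same change on two cores in this assay, no change at the digits printed (within the scatter) from compound 1 to compound 2 and a 4.4-fold lower number (0.64 log units; beyond the scatter) from compound 3 to compound 4, 4.4-fold (0.64 log units) apart, beyond the scatter of two such steps The step on the core of compound 3 is a 4.4-fold lower number from compound 3 to compound 4 (0.64 log units; beyond the scatter), so the flat result on the core of compound 1 did not carry over, and the effect of adding this fluoro depends on the core it is added to. This rests on a single pair of compounds for each core, however, so it does not show why the cores respond differently, nor whether the same split would hold for any other change or in any other assay.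

Still open, from the compounds shown here alone, is whether a chloro or a methoxy group in place of this fluoro would also give a flat step on one core and a clear step on the other. A second open question is whether an amine or a carboxylic acid on the same aromatic ring would separate the two cores in the same way.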